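The compounds below may be only part of what the source reports. "The series", "measured", "known", "first", "only" and "open" are said of these compounds alone.

Working notes on the iodoacetamide series. Three linker lengths have been measured in an assay on isolated protein for inhibition of hexokinase-1 (Rattus norvegicus), with a stated time of 6 h, tested at 10 mM; on this read-out higher numbers stand for more inhibition at the one concentration tested (going by the name of the read-out) and lower numbers for less inhibition. Compound 1 `O=C(CI)NCCCCCC(=O)NCCCCCCNc1ncnc2c1ncn2[C@@H]1O[C@H](COP(=O)(O)OP(=O)(O)OP(=O)(O)O)[C@@H](O)[C@H]1O` gives 0%. Compound 2 `O=C(CI)NCCCCC(=O)NCCCCCCNc1ncnc2c1ncn2[C@@H]1O[C@H](COP(=O)(O)OP(=O)(O)OP(=O)(O)O)[C@@H](O)[C@H]1O` gives 0%, and compound 3 `O=C(CI)NCCC(=O)NCCCCCCNc1ncnc2c1ncn2[C@@H]1O[C@H](COP(=O)(O)OP(=O)(O)OP(=O)(O)O)[C@@H](O)[C@H]1O` gives 0%. The steps between them are flat: no change at the digits printed from compound 1 to compound 2 (within the scatter), no change at the digits printed from compound 1 to compound 3 (within the scatter) and no change at the digits printed from compound 2 to compound 3 (within the scatter). Compound 3 therefore stands level with compounds 1 and 2 in this assay; no ordering among the three can be read from these numbers.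

Compound 4 `O=C(CI)NCCCC(=O)NCCCCCCNc1ncnc2c1ncn2[C@@H]1O[C@H](COP(=O)(O)OP(=O)(O)OP(=O)(O)O)[C@@H](O)[C@H]1O` is the next member of the same series, and differs from compound 3 as follows: (((iodomethyl)carbonyl)amino)methyl in place of ((iodomethyl)carbonyl)amino on a saturated chain carbon, two bonds along the chain from a carbonyl carbon.

Among the measured compounds shown here, the steps that bear on this change are those already in hand, since each of them is the same kind of alteration, a lengthening or shortening of the saturated chain by one or more methylene units, and each of them was flat within the scatter. Nothing in the measured set suggests that chain length moves the read-out, and compound 4 sits between compound 3 and compound 2 in chain length. The step in this assay is therefore expected to be none beyond the scatter, no change at the digits printed from compound 3 to compound 4 (within the scatter). Compound 4 is estimated at 0%, with a range from 0% to 10%.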

Compound 4, a percentage reported as inhibition, at one concentration (the size of the read-out at that concentration, not a potency): 0%
Compound 4: the middle estimate sits on the measured number at the digits printed; the range from low to high includes it.
By their numbers in this assay, from the lowest: compounds 1, 2, 3 and 4 (each within the scatter of the next).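

With compound 4, each chain length shown in this set is level in this assay, and all three new steps are flat: no change at the digits printed from compound 3 to compound 4 (within the scatter) and no change at the digits printed from compound 2 to compound 4 (within the scatter) and no change at the digits printed from compound 1 to compound 4 (within the scatter). The exchange of ((iodomethyl)carbonyl)amino for (((iodomethyl)carbonyl)amino)methyl on a saturated chain carbon can now be compared with the matching change on a second core, and the two steps agree: the same change on two cores in this assay, no change at the digits printed (within the scatter) from compound 1 to compound 2 and no change at the digits printed (within the scatter) from compound 4 to compound 3, 0 percentage points apart, within the scatter of two such steps. The same holds for the larger shortening by two chain units, now also seen on two cores: the same change on two cores in this assay, no change at the digits printed (within the scatter) from compound 2 to compound 3 and no change at the digits printed (within the scatter) from compound 1 to compound 4, 0 percentage points apart, within the scatter of two such steps.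

Since all four compounds read the same at the one concentration tested, this assay gives no ordering by chain length, and none of the four goes against that flat result, though it cannot show whether the chain would matter in a series with measurable inhibition. Still open, on these data alone, is whether a longer chain, or an amine, a carboxylic acid or a bromoacetyl group in place of the iodoacetyl end, would give a different reading in this assay.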